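This account rests on a few compounds, and the source may have more. Where it says the series, first, only, none or still open, it means among the compounds named here.

Three compounds of a shared core were measured in a functional assay on Huh-7 cells (Homo sapiens) for inhibition, read by sulforhodamine B assay, with a stated time of 72 h; a higher number here means a weaker inhibitor, a lower number a stronger inhibitor. Compound 1, `CC(c1ccc(-c2ccccc2)c(F)c1)c1nnc2n1N=C(c1ccc(OC(F)(F)F)cc1)CS2`, gives 8400 nM. Compound 2, `CC(C)Cc1ccc(C(C)c2nnc3n2N=C(c2ccc(Br)cc2)CS3)cc1`, gives 4900 nM. Compound 3, `COc1ccc2cc(C(C)c3nnc4n3N=C(c3ccc(Br)cc3)CS4)ccc2c1`, gives 9300 nM. Compound 2 has the lowest of the three numbers, but its gaps to compound 1 and to compound 3 both lie within the usual scatter, so no order among the three can be read from these values.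

Compound 4, `COc1ccc(C2=Nn3c(nnc3C(C)c3ccc(CC(C)C)cc3)SC2)cc1`, has not been measured in this assay. It differs from compound 2 in one place: methoxy in place of bromo on an aromatic carbon. Among the measured compounds shown here, no measured pair in this set differs by such a change, so nothing in the data shows what a methoxy in place of a bromo does here. The expectation is therefore a step of small size, not beyond the scatter, with no clear direction. Compound 4 is estimated at 6000 nM, with a range from 2500 nM to 15000 nM, which means an expected step of a 1.2-fold higher number from compound 2 to compound 4 (0.09 log units; within the scatter).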

Compound 4, half-maximal inhibitory concentration: 3700 nM
Compound 4: the middle estimate sits 1.6-fold (0.21 log units) above what was measured; the range from low to high includes it.
By their numbers in this assay, from the lowest: compounds 4, 2, 1 and 3 (each within the scatter of the next, the first and the last beyond it).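

In this assay, among the compounds shown here, the exchange of 4-bromophenyl for 4-methoxyphenyl gives a 1.3-fold lower number from compound 2 to compound 4 (0.12 log units; within the scatter) and is the only one-place comparison in the set. At this position, on an aromatic carbon of the six-membered ring, a bromo and a methoxy, which brings one hydrogen-bond acceptor and one more heavy atom, give numbers that cannot be told apart. No independent measurement on these compounds bears on this result.

From the compounds shown here alone, whether an amine, a carboxylic acid or a longer alkoxy chain at this position would give a step beyond the scatter stays open. Going by these compounds, it is also open whether the same exchange would read alike in compound 3, which carries the same 4-bromophenyl group on a different side of the shared core.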